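The compounds below may be only part of what the source reports. "The series", "measured", "known", "first", "only" and "open" are said of these compounds alone.

Measured in an ADME assay on microsomes from liver (Homo sapiens) for metabolic stability, read by HPLC, with a stated time of 60 min, tested at 0.2 mg/mL; a higher number here means faster removal of the compound, a lower number slower removal:
- compound 1 `O=C(NCc1ccc(Cl)cc1Cl)[C@@H]1CCC(=O)N1c1ccsc1`: 762 mL.min-1.g-1
- compound 2 `O=C(NCc1ccc(Cl)cc1Cl)[C@@H]1CCC(=O)N1c1ccoc1`: 630 mL.min-1.g-1

Within the data shown here, with 630 mL.min-1.g-1, compound 2 cannot be told apart from compound 1, the only other measured compound, as the two values lie within the scatter of each other. Compound 3 `O=C(NCc1ccc(Cl)cc1Cl)[C@@H]1CCC(=O)N1c1nccs1` carries 1,3-thiazol-2-yl in place of furan-3-yl on an amide-type nitrogen in a ring.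

Among the measured compounds shown here, one measured step bears on this change, a 1.2-fold lower number from compound 1 to compound 2 (0.08 log units; within the scatter), which also swaps one five-membered aromatic ring for another on that nitrogen. For the measured compounds named here, no measured compound carries 1,3-thiazol-2-yl, which leaves that step a weak guide. The expectation in this assay is therefore for no clear change beyond the scatter, with the expected step being a 1.3-fold lower number from compound 2 to compound 3 (0.10 log units; within the scatter). Compound 3 is estimated at 500 mL.min-1.g-1, with an expected range of 220 mL.min-1.g-1 to 950 mL.min-1.g-1.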

Compound 3, intrinsic clearance in microsomes: 253 mL.min-1.g-1
The estimate for compound 3 lay 2.0-fold (0.30 log units) above the measured number, and the stated range covers the measured number.
By their numbers in this assay, from the lowest: compound 3; then compounds 2 and 1 (each within the scatter of the next).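

In this assay the ring on the amide-type nitrogen does matter: 1,3-thiazol-2-yl in place of furan-3-yl gives a 2.5-fold lower number from compound 2 to compound 3 (0.40 log units; beyond the scatter), a separation that compounds 1 and 2 alone did not show. Against thiophen-3-yl the same ring gives a 3.0-fold lower number from compound 1 to compound 3 (0.48 log units; beyond the scatter), so compound 3 stands apart from both earlier compounds, and 1,3-thiazol-2-yl, the only one of the three rings with 2 hetero atoms, is the only one that separates from the others, though three compounds are too few to call this a pattern. No supporting data bear on why this ring gives the lower number.

Open, from the compounds shown here alone, is whether a 1,3-oxazol-2-yl or pyridin-2-yl ring on the same nitrogen would give a similarly low number. Also open, going by these compounds, is how a methyl group or a carboxylic acid on the 1,3-thiazol-2-yl ring would shift it.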